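Replacing the 3,4-dimethoxyphenyl group of compound 1

The compounds below may be only part of what the source reports. "The series", "measured", "known", "first", "only" and "open" are said of these compounds alone.

Values so far in a functional assay on COLO 205 cells (Homo sapiens) for inhibition, read by sulforhodamine B assay; on this read-out higher numbers stand for weaker inhibition of growth and lower numbers for stronger inhibition of growth:
Compound 1 `COc1ccc(-c2ccc(-c3ccc(-c4nc5cc(C)ccc5[nH]4)cc3)cc2)cc1OC` gives 2320 nM
Compound 2 `COc1ccc(-c2ccc(-c3ccc(-c4nc5c(O)cccc5[nH]4)cc3)cc2)cc1OC` gives 1320 nM

Within the data shown here, compound 1 stands level with compound 2, the only other measured compound, and their two values lie within the scatter of each other. Compound 3 `Cc1ccc2[nH]c(-c3ccc(-c4ccc(-c5ccc(F)cc5)cc4)cc3)nc2c1` keeps the core of compound 1 and carries 4-fluorophenyl in place of 3,4-dimethoxyphenyl on an aromatic carbon, para to a large group (4-fluorophenyl in place of 3,4-dimethoxyphenyl on an aromatic carbon). Among the measured compounds shown here, the only measured step (a 1.8-fold lower number from compound 1 to compound 2 (0.24 log units; within the scatter)) bears on this change only loosely. It replaces 5-methyl-1H-benzimidazol-2-yl with 4-hydroxy-1H-benzimidazol-2-yl, a different place in the structure. For the measured compounds named here, no measured compound shows the effect of changing the 3,4-dimethoxyphenyl group, and the data give no direction. A step beyond the scatter in this assay is therefore not expected, although the range below stays wide on both sides. The estimated change is small (a 1.1-fold higher number from compound 1 to compound 3 (0.03 log units; within the scatter)). Compound 3 is expected at 2500 nM as a central value, with an estimated range from 800 nM to 8000 nM for repeated measurements.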

Compound 3, concentration for 50% growth inhibition: 100000 nM
Beside the measured number, compound 3's estimate is 40-fold (1.60 log units) below it; the measured number lies above the stated range.
By their numbers in this assay, from the lowest: compounds 2 and 1 (each within the scatter of the next); then compound 3.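

In this assay, the aromatic carbon para to a large group proves sensitive to the group it carries: exchanging 3,4-dimethoxyphenyl for 4-fluorophenyl gives a 43-fold higher number from compound 1 to compound 3 (1.63 log units; beyond the scatter), which means much weaker inhibition of growth. Among these compounds, the only earlier step, a 1.8-fold lower number from compound 1 to compound 2 (0.24 log units; within the scatter), was made at a different place in the structure and stayed within the scatter, so it gave no sign that this end of the molecule could matter so much. Nothing measured here on the compounds or their properties accounts for the size of the new step.

This single exchange cannot show whether the change in growth inhibition follows from the loss of 3,4-dimethoxyphenyl or from the arrival of 4-fluorophenyl, since both happen in the same step. The compounds shown also leave open whether an amine, a carboxylic acid or a single methoxy group on that outer ring would keep compound 3 close to the level of compound 1, and whether the 4-hydroxy-1H-benzimidazol-2-yl group of compound 2 would meet the same loss alongside 4-fluorophenyl.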